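Hydroxy placement on the saturated ring: notes toward compound 4

This account rests on a few compounds, and the source may have more. Where it says the series, first, only, none or still open, it means among the compounds named here.

Measured so far:
- compound 1, `C=C1C(=O)O[C@@H]2[C@@H]1C[C@@H](O)[C@H](C)[C@@](O)(C(=O)CC(C)O)[C@H]2OC(=O)C(C)CC`, gives 12.7 ug/mL in a functional assay on KB cells (Homo sapiens) for cytotoxicity; on this read-out higher numbers stand for an effect only at larger amounts of compound and lower numbers for an effect already at smaller amounts.
- compound 2, `C=C1C(=O)O[C@@H]2[C@@H]1CC[C@H](C)[C@@](O)(C(=O)/C=C/C)[C@H]2OC(=O)/C(C)=C\C`, gives 0.4 ug/mL in this assay.
- compound 3, `C=C1C(=O)O[C@@H]2[C@@H]1C[C@@H](O)[C@H](C)[C@@](O)(C(=O)/C=C/C)[C@H]2OC(=O)/C(C)=C\C`, gives 0.3 ug/mL in this assay.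

Compound 2 stands second highest of the three numbers in this assay. Its nearest neighbour is compound 3, the two values lying within the scatter of each other; compound 1 reads far higher, beyond the scatter.

Compound 4, `C=C1C(=O)O[C@@H]2[C@@H]1[C@@H](O)C[C@H](C)[C@@](O)(C(=O)/C=C/C)[C@H]2OC(=O)/C(C)=C\C`, differs from compound 2 as follows: hydroxy in place of hydrogen on a saturated ring carbon.

Among the compounds with values here, the one measured step of this kind, a 1.3-fold lower number from compound 2 to compound 3 (0.12 log units; within the scatter), placed the hydroxy on a different saturated ring carbon and stayed within the scatter. Within the data shown here, no measured pair covers the position taken in compound 4, so that step is the only guide. On it, compound 4 is expected to move little from compound 2 in this assay, with no change at the digits printed from compound 2 to compound 4 (within the scatter) not going beyond the scatter in either direction. Compound 4 is therefore estimated at 0.4 ug/mL, with a range from 0.15 ug/mL to 1.2 ug/mL.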

Compound 4, concentration for half-maximal effect: 1.4 ug/mL
Compound 4: the middle estimate sits 3.5-fold (0.54 log units) below what was measured; the whole stated range lies below it.
By their numbers in this assay, from the lowest: compounds 3 and 2 (each within the scatter of the next); then compound 4; then compound 1.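

Hydroxy in place of hydrogen on the seven-membered ring does not read the same at every carbon. In this assay, the carbon two ring bonds from the ring atom that bears a methyl group shows a 3.5-fold higher number from compound 2 to compound 4 (0.54 log units; beyond the scatter) and so goes beyond the scatter, while the earlier placement shows a 1.3-fold lower number from compound 2 to compound 3 (0.12 log units; within the scatter) and stays within it. The outcome of this change therefore depends on its position, and no data at hand explain why the two carbons differ.

On these data alone, it remains open whether a methoxy group or an amine on this same carbon would read closer to compound 2 or to compound 4. Also open, as far as these compounds go, is whether the hydroxy with the opposite stereochemistry at this carbon would give the same shift.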